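Removing the para methyl from an aryl carbamate selenocyanate

This account rests on a few compounds, and the source may have more. Where it says the series, first, only, none or still open, it means among the compounds named here.

Of the compounds shown here, three sharing one core have been measured in a functional assay on MCF7 cells (Homo sapiens) for cytotoxicity, read by MTT assay, with a stated time of 72 h; a lower number here means a stronger inhibitor of growth, a higher number a weaker inhibitor of growth. Compound 1 `CCCCOC(=O)Nc1ccc([Se]C#N)cc1` gives 20200 nM. Compound 2 `N#C[Se]c1ccc(NC(=O)Oc2ccc(F)cc2)cc1` gives 33300 nM. Compound 3 `Cc1ccc(OC(=O)Nc2ccc([Se]C#N)cc2)cc1` gives 39900 nM. Compound 3 sits at the upper end of a narrow span: its gaps to compound 2 and to compound 1 both fall within the scatter, so the three numbers cannot be told apart.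

Compound 4 `N#C[Se]c1ccc(NC(=O)Oc2ccccc2)cc1` is not yet measured. It differs from compound 3 by hydrogen in place of methyl on an aromatic carbon. Among the measured compounds shown here, the one measured step that touches the same position is a 1.2-fold higher number from compound 2 to compound 3 (0.08 log units; within the scatter), where swapping one small group for another at that carbon left the number essentially where it was. Nothing in these data suggests that a change at this position matters beyond the scatter, so a step of similar size is expected here, with no clear direction.

Compound 4 is therefore expected to give 35000 nM in this assay, with a likely range from 15000 nM to 80000 nM, meaning an expected step of a 1.1-fold lower number from compound 3 to compound 4 (0.06 log units; within the scatter).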

Compound 4, concentration for total growth inhibition: 35900 nM
Compound 4: middle estimate off by 1.0-fold (0.01 log units), on the low side, within the range that was stated.
By their numbers in this assay, from the lowest: compounds 1, 2, 4 and 3 (each within the scatter of the next).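

In this assay, taking away the methyl group gives a step within the scatter (a 1.1-fold lower number from compound 3 to compound 4 (0.05 log units; within the scatter)), and hydrogen in place of fluoro does the same (a 1.1-fold higher number from compound 2 to compound 4 (0.03 log units; within the scatter)), so hydrogen, methyl and fluoro on this aromatic carbon cannot be told apart. Compound 4, with its bare phenyl, also allows a direct look at phenyl in place of butyl on the oxygen, and that step too stays within the scatter (a 1.8-fold higher number from compound 1 to compound 4 (0.25 log units; within the scatter)). No supporting measurement is available to account for these results.

The compounds shown include no group on this carbon that moves the number beyond the scatter, so this position's influence remains undefined. From the compounds shown here alone, whether an amine, a carboxylic acid or a longer chain there would shift growth inhibition stays open.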